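Dimethylphenyl sulfonamides: from compound 2 to compound 3

The source may hold more compounds than are shown below. What is called first, only, known or untested is meant among the compounds shown, and "the series" means these compounds.

Measured so far in a functional assay on K562 cells (Homo sapiens) for antiproliferative activity, read by sulforhodamine B assay, with a stated time of 48 h (on this read-out lower numbers stand for stronger inhibition and higher numbers for weaker inhibition), as the read-out:
- compound 1 `O=C1NCCN1c1ccc(S(=O)(=O)Nc2cccc(Br)c2)cc1` gives 87 nM in this assay
- compound 2 `Cc1cc(C)cc(NS(=O)(=O)c2ccc(N3CCNC3=O)cc2)c1` gives 110 nM in this assay

Among the measured compounds shown here, compound 2 stands level with its only neighbour on these numbers. That gap is a 1.3-fold higher number from compound 1 to compound 2 (0.10 log units; within the scatter) and no order can be drawn from it. The next structure is compound 3 `Cc1ccc(C)c(NS(=O)(=O)c2ccc(N3CCNC3=O)cc2)c1` which carries 2,5-dimethylphenyl in place of 3,5-dimethylphenyl on a sulfonamide nitrogen with the same atoms joined differently. For the measured compounds named here, the one measured step bearing on this change also exchanged the group at that place. Going by the values given here, no measured compound carries 2,5-dimethylphenyl, so the guide is indirect and the range stays wide. Among the compounds with values here, with a 1.3-fold higher number from compound 1 to compound 2 (0.10 log units; within the scatter) as the sole precedent, no shift beyond the scatter is expected in this assay and the estimated change is a 1.2-fold higher number from compound 2 to compound 3 (0.07 log units; within the scatter) as a working figure. Compound 3 is expected at 130 nM with 50 nM to 340 nM as the estimated range.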

Compound 3, half-maximal inhibitory concentration: 72 nM
Beside the measured number, compound 3's estimate is 1.8-fold (0.26 log units) above it, within the range that was stated.
By their numbers in this assay, from the lowest: compounds 3, 1 and 2 (each within the scatter of the next).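

In this assay, the step of a 1.5-fold lower number from compound 2 to compound 3 (0.18 log units; within the scatter) shows that 2,5-dimethylphenyl in place of 3,5-dimethylphenyl on a sulfonamide nitrogen, with the same atoms joined differently, leaves the number within the scatter. Among the compounds shown here, the step of a 1.2-fold lower number from compound 1 to compound 3 (0.08 log units; within the scatter) is also within the scatter, so 3-bromophenyl, 3,5-dimethylphenyl and 2,5-dimethylphenyl cannot be put in any order at this place, and this series so far gives no sign that the arrangement of the methyl groups matters in this read-out. No supporting data bear on these numbers, so nothing can be said about what lies behind them.

As far as these compounds go, it remains open whether a phenyl carrying an amine or a carboxylic acid, or a longer alkyl chain in place of the phenyl, would give a step beyond the scatter at this sulfonamide nitrogen. From the compounds shown here alone, whether changes to the shared core would do so also remains open.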